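Enlarging a Methyl to tert-Butyl on a Diaryl Urea

The source may report more compounds than this note shows. Statements on the series, on what has been measured and on what is new or still open speak of the compounds shown alone.

Compound 1 `Cc1ccc(NC(=O)Nc2cccc(CNc3nccnc3Cl)c2)cc1C` and compound 2 `Cc1ccc(NC(=O)Nc2cccc(CNc3nccnc3Cl)c2)cc1` share a urea core that carries an aminopyrazine-bearing benzyl arm. In a functional assay on HepG2 cells (Homo sapiens) for antiproliferative activity, read by MTT assay, with a stated time of 48 h (on this read-out lower numbers stand for stronger inhibition and higher numbers for weaker inhibition), compound 1 gives 10700 nM, and in this assay compound 2 gives 11500 nM. Among the compounds with values here, the single step between them, a 1.1-fold higher number from compound 1 to compound 2 (0.03 log units; within the scatter), shows that losing one methyl from the aryl ring leaves the read-out essentially where it was. Compound 2 therefore sits beside compound 1 with no spread between them beyond the usual scatter; the two numbers are indistinguishable.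

Compound 3 `CC(C)(C)c1ccc(NC(=O)Nc2cccc(CNc3nccnc3Cl)c2)cc1` carries the change (tert-butyl in place of methyl on an aromatic carbon). Within the data shown here, the only measured step that bears on this position is a 1.1-fold higher number from compound 1 to compound 2 (0.03 log units; within the scatter), which concerned a methyl at a different site and fell within the scatter. Among the measured compounds shown here, no measured pair tests a group as large as tert-butyl, so the data give no basis for expecting a shift beyond the scatter in either direction in this assay. Compound 3 is therefore expected to give about 11000 nM, with a range from 5000 nM to 25000 nM, meaning an expected step of a 1.0-fold lower number from compound 2 to compound 3 (0.02 log units; within the scatter).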

Compound 3, half-maximal inhibitory concentration: 7550 nM
Estimate against measurement, compound 3: 1.5-fold (0.16 log units) above; low and high end bracket the measured number.
By their numbers in this assay, from the lowest: compounds 3, 1 and 2 (each within the scatter of the next).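

In this assay, tert-butyl in place of methyl on an aromatic carbon, para to a large group, gives a 1.5-fold lower number from compound 2 to compound 3 (0.18 log units; within the scatter) and so stays within the scatter. The earlier pair carried the same methyl at this position and could say nothing about a larger group here, whereas this step shows that going from 1 heavy atom to 4 heavy atoms, all carbon and with no hydrogen-bond donors or acceptors on either side, does not separate compound 3 from compound 2 on this read-out. With a single step inside the scatter, the result supports no trend with group size, and no measurement at hand offers an account of it.

The compounds shown leave open whether a group of a different kind at this position, such as an amine, a carboxylic acid or a methoxy group, would move the number beyond the scatter. They also leave open whether a longer chain, or a tert-butyl group on the core of compound 1 with its second methyl kept, would behave as this replacement does.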